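The compounds below may be only part of what the source reports. "The series", "measured", "known", "first", "only" and "open" are said of these compounds alone.

Three compounds sharing one core have been measured in a functional assay on HCT-116 cells (Homo sapiens) for inhibition, read by MTT assay, with a stated time of 48 h; on this read-out higher numbers stand for weaker inhibition and lower numbers for stronger inhibition:

Compound 1, `C/C=C/C=C/C(=O)N(Cc1ccc(OC)c(O)c1)c1cc(OC)c(OC)c(OC)c1`: 180 nM
Compound 2, `COc1ccc(CN(C(C)=O)c2cc(OC)c(OC)c(OC)c2)cc1O`: 270 nM
Compound 3, `C=C(C)C(=O)N(Cc1ccc(OC)c(O)c1)c1cc(OC)c(OC)c(OC)c1`: 200 nM

The three numbers lie close together. Compound 3 stands second highest of the three, with compound 1 nearest and compound 2 furthest, and its steps to both fall within the scatter, so no order among them can be drawn. The measured steps all sit on the carbonyl carbon: a 1.5-fold higher number from compound 1 to compound 2 (0.18 log units; within the scatter), a 1.1-fold higher number from compound 1 to compound 3 (0.05 log units; within the scatter) and a 1.4-fold lower number from compound 2 to compound 3 (0.13 log units; within the scatter). Each of these changes at the carbonyl carbon left this assay essentially unchanged.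

Compound 4, `COc1ccc(CN(C(=O)/C=C/CBr)c2cc(OC)c(OC)c(OC)c2)cc1O`, is the next compound to be measured. It differs from compound 3 as follows: 3-bromoprop-1-en-1-yl in place of 1-methylethenyl on a carbonyl carbon. This is again a change at the carbonyl carbon whose other neighbour is the amide-type nitrogen, the same place where the three measured steps were all within the scatter. Those steps are therefore the ones that bear on this change, and none of them was large. On that basis compound 4 is expected to show no step beyond the scatter, with a 1.1-fold higher number from compound 3 to compound 4 (0.02 log units; within the scatter) as the expected step. The estimate for compound 4 is 210 nM, within a range from 90 nM to 500 nM.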

Compound 4, half-maximal inhibitory concentration: 59 nM
The estimate for compound 4 lay 3.6-fold (0.55 log units) above the measured number; the measured number lies below the stated range.
By their numbers in this assay, from the lowest: compound 4; then compounds 1, 3 and 2 (each within the scatter of the next).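

At the carbonyl carbon whose other neighbour is the amide-type nitrogen, methyl, 1-methylethenyl and penta-1,3-dien-1-yl could not be told apart in this assay, but 3-bromoprop-1-en-1-yl can, with a 3.4-fold lower number from compound 3 to compound 4 (0.53 log units; beyond the scatter) and a 4.6-fold lower number from compound 2 to compound 4 (0.66 log units; beyond the scatter) as well as a 3.1-fold lower number from compound 1 to compound 4 (0.48 log units; beyond the scatter) as steps beyond the scatter. The position therefore does respond to the group placed there, and a double bond in that group is not enough on its own: compound 1 and compound 3 carry one, yet both stay within the scatter of compound 2, which has none. No measurement shown here gives a reason for the lower number of compound 4.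

The compounds shown do not separate the contribution of the bromine from that of the chain carrying it, since 3-bromoprop-1-en-1-yl is the only group here with a bromine atom. A 3-chloroprop-1-en-1-yl group, a saturated 3-bromopropyl chain or a prop-1-en-1-yl chain ending in an amine would each bear on that question.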